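Trimming the ester of compound 2

A few compounds are considered here, and "the series" means these few. Any claim that something is new, unique, unknown or untested is made for them only; others in the source may bear on it.

For the measured compounds named here, three related compounds have numbers so far in a functional assay on A549 cells (Homo sapiens) for cytotoxicity, read by MTT assay, with a stated time of 72 h (a lower number here means a stronger inhibitor, a higher number a weaker inhibitor), and compound 2 (`CCOC(=O)c1sc2cccc(C)c2c1Nc1cc(OC)c(OC)c(OC)c1`) gives 6250 nM in it. Compound 3 (`COC(=O)c1sc2ncccc2c1Nc1cc(OC)c(OC)c(OC)c1`) gives 3850 nM there, a gap to compound 2 that lies within the scatter. Against these two, compound 1 (`COC(=O)c1sc2cc(C)ccc2c1Nc1cc(OC)c(OC)c(OC)c1`) gives 10.8 nM, far beyond the scatter from compound 2, which therefore sits at the high end of the numbers shown, alongside compound 3.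

Compound 4 (`COC(=O)c1sc2cccc(C)c2c1Nc1cc(OC)c(OC)c(OC)c1`) has not been measured. It departs from compound 2 by one change, (hydrogen in place of methyl on a saturated chain carbon bound to an oxygen next to a carbonyl group), with hydrogen in place of methyl on a saturated chain carbon bound to an oxygen next to a carbonyl group, so ethoxycarbonyl becomes methoxycarbonyl.

Going by the values given here, no measured pair isolates this change, so its size can only be judged indirectly. Compound 3 and compound 1 both carry methoxycarbonyl, yet compound 3 stays at 3850 nM while compound 1 reaches 10.8 nM, so that group alone does not go with a low number. Only a modest move toward a lower number is expected, quite possibly within the scatter. The estimated change is a 2.5-fold lower number from compound 2 to compound 4 (0.40 log units; beyond the scatter) in this assay, and no large gain is expected from it. For compound 4 the estimate is 2500 nM, with an expected range from 500 nM to 9000 nM as its limits.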

Compound 4, half-maximal inhibitory concentration: 4580 nM
Compound 4: the middle estimate sits 1.8-fold (0.26 log units) below what was measured; low and high end bracket the measured number.
By their numbers in this assay, from the lowest: compound 1; then compounds 3, 4 and 2 (each within the scatter of the next).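

Trimming ethoxycarbonyl to methoxycarbonyl gives the first direct reading at this place: in this assay the change is a 1.4-fold lower number from compound 2 to compound 4 (0.14 log units; within the scatter), so removing that one methyl from the saturated chain carbon bound to an oxygen next to a carbonyl group leaves the number essentially where it was. It also sharpens what compound 3 had only hinted at, since compound 1 (10.8 nM) and compound 4 (4580 nM) both carry methoxycarbonyl, and shortening the ester of compound 2 therefore does nothing to close the distance to compound 1. No measurement on hand bears on the reason for this result.

The compounds shown cover only ethoxycarbonyl and methoxycarbonyl here, so it remains open whether a longer chain such as propoxycarbonyl, a free carboxylic acid or an amide at the same place would stay equally flat or move the number. Also open, from the compounds shown here alone, is what sets compound 1 so far apart from compound 2, compound 3 and compound 4, as the ester step settles only that the answer does not lie in the ethyl-to-methyl change.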